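Swapping the aryl group on the sulfonamide nitrogen

A few compounds are considered here, and "the series" means these few. Any claim that something is new, unique, unknown or untested is made for them only; others in the source may bear on it.

Of the compounds shown here, two share one core and have been measured in a physicochemical assay for lipophilicity, at pH 7.4; on this read-out higher numbers stand for higher lipophilicity and lower numbers for lower lipophilicity. Compound 1 `CCc1ccc(N(C2CCC2)S(=O)(=O)c2ccc3c(c2)C(O)CC(C2CCOCC2)O3)cc1` gives 3.69. Within the data shown here, compound 2 `CCc1ccc(N(CC(C)C)S(=O)(=O)c2ccc3c(c2)C(O)CC(C2CCOCC2)O3)cc1` gives 4.12, the higher of the two numbers; the only measured step, a number 0.43 log units higher from compound 1 to compound 2 (beyond the scatter), places isobutyl in place of cyclobutyl on a sulfonamide nitrogen.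

Compound 3 `CC(C)CN(c1cc2ccccc2s1)S(=O)(=O)c1ccc2c(c1)C(O)CC(C1CCOCC1)O2` has not yet been measured. It differs from compound 2 in one place: 1-benzothiophen-2-yl in place of 4-ethylphenyl on a sulfonamide nitrogen. Among the measured compounds shown here, the measured step between compound 1 and compound 2 concerns the saturated group on that nitrogen, not the aromatic group, so it does not bear directly on this change; there is no measured step in which one aromatic group on the nitrogen replaces another. The two groups that are exchanged are of similar size, one heavy atom apart, and both are aromatic. The step from compound 2 to compound 3 is therefore expected to be small, within or close to the scatter, as a number 0.12 log units lower from compound 2 to compound 3 (within the scatter). For compound 3 the expected value in this assay is 4, with a range from 3.5 to 4.5.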

Compound 3, distribution coefficient: 3.92
Compound 3: middle estimate off by 0.08 log units, on the high side, and the stated range covers the measured number.
By their numbers in this assay, from the lowest: compounds 1, 3 and 2 (each within the scatter of the next, the first and the last beyond it).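

Compounds 1 and 2 differ only in the saturated group on the sulfonamide nitrogen, whereas compound 3 changes the aromatic group on that same nitrogen. In this assay, placing 1-benzothiophen-2-yl where 4-ethylphenyl stood gives a number 0.20 log units lower from compound 2 to compound 3 (within the scatter), so this pair cannot be told apart on this read-out. That holds even though the entering group brings a five-membered aromatic ring containing sulfur, and the exchange therefore shows that this aromatic group can be replaced by a quite different one without a change that stands clear of the scatter; nothing available here accounts for this result.

Open, on these data alone, is whether the same exchange would give a similar result with cyclobutyl rather than isobutyl on the nitrogen, since that would show if the two changes act independently in this assay. Also open, as far as these compounds go, is how the read-out would respond to aromatic groups of another kind on this nitrogen, such as a pyridine ring or a phenyl ring carrying an amine or a carboxylic acid.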